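The compounds below may be only part of what the source reports. "The series", "measured", "known", "first", "only" and "open" are said of these compounds alone.

Measured in a functional assay on HeLa cells (Homo sapiens) for inhibition, read by MTT assay, with a stated time of 48 h; a higher number here means a weaker inhibitor, a lower number a stronger inhibitor:
Compound 1 `COc1ccc(/C=C2\SC(=O)N(CCNC(=O)Nc3c(C)n(C)n(-c4ccccc4)c3=O)C2=O)cc1`: 6180 nM
Compound 2 `Cc1c(NC(=O)NCCN2C(=O)S/C(=C\c3ccc([N+](=O)[O-])cc3)C2=O)c(=O)n(-c2ccccc2)n1C`: 37700 nM
Compound 3 `COc1ccc(/C=C2\SC(=O)N(CC(=O)Nc3c(C)n(C)n(-c4ccccc4)c3=O)C2=O)cc1`: 64800 nM

Compound 3 gives 64800 nM, the highest number of the three. That value lies within the scatter of compound 2 and is clearly higher than that of compound 1.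

Compound 4 `Cc1c(NC(=O)CN2C(=O)S/C(=C\c3ccc(Cl)cc3)C2=O)c(=O)n(-c2ccccc2)n1C` has not yet been measured. It differs from compound 3 by one change: chloro in place of methoxy on an aromatic carbon. This is chloro in place of methoxy on an aromatic carbon, para to a large group, so that 4-methoxyphenyl becomes 4-chlorophenyl.

Among the compounds with values here, no chloro compound has been measured so far. The closest evidence is a 6.1-fold higher number from compound 1 to compound 2 (0.79 log units; beyond the scatter), where nitro replaces methoxy on a chain different from that of compound 3. Since nitro is not chloro, this step offers only a tentative direction. A smaller rise in this assay is expected, and a result within the scatter would be unsurprising. The expected change is a 1.3-fold higher number from compound 3 to compound 4 (0.12 log units; within the scatter). Compound 4 is estimated at 85000 nM, with an expected range of 25000 nM to 250000 nM.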

Compound 4, half-maximal inhibitory concentration: 20000 nM
Compound 4: middle estimate off by 4.3-fold (0.63 log units), on the high side, outside the stated range (below it).
By their numbers in this assay, from the lowest: compound 1; then compounds 4, 2 and 3 (each within the scatter of the next, the first and the last beyond it).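

In this assay chloro in place of methoxy on an aromatic carbon, para to a large group, lowers the number (a 3.2-fold lower number from compound 3 to compound 4 (0.51 log units; beyond the scatter)), so this is the first change at this position shown to give a stronger inhibitor. The only earlier step at this position went the other way, with nitro entering on a different chain (a 6.1-fold higher number from compound 1 to compound 2 (0.79 log units; beyond the scatter)), so replacing methoxy here has no single direction across the compounds shown, and the outcome depends on the group that enters, the chain, or both. Nothing measured here accounts for either step.

The compounds shown leave open whether chloro would also lower the number on the chain of compound 1, where only methoxy and nitro appear. They also leave open how an amine or a fluoro group on the same aromatic carbon would read in this assay.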